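The source may hold more compounds than are shown below. What is called first, only, known or untested is meant among the compounds shown, and "the series" means these compounds.

Measured so far:
compound 1 `Nc1nc(Cl)c2ncn(Cc3ccccc3CCl)c2n1`: 39800 nM
compound 2 `ClCc1ccc(Cn2cnc3c(Cl)nc(Cl)nc32)cc1`: 34700 nM

In a functional assay on OVCAR-5 cells (Homo sapiens) for cytotoxicity, read by sulforhodamine B assay, with a stated time of 48 h (a higher number here means a weaker inhibitor of growth, a lower number a stronger inhibitor of growth), compound 1 gives 39800 nM, the top of the two numbers shown, though compound 2 at 34700 nM sits within the scatter of it. Compound 3 `ClCc1ccccc1Cn1cnc2c(Cl)ncnc21` is not yet measured. It differs from compound 1 in one place: hydrogen in place of amino on an aromatic carbon. Within the data shown here, no pair of measured compounds shows this change, so nothing here tells its size. The expected step is small, likely none beyond the scatter, in either direction. Compound 3 is expected to give about 45000 nM, ranging from 12000 nM to 170000 nM. That estimate means an expected step of a 1.1-fold higher number from compound 1 to compound 3 (0.05 log units; within the scatter).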

Compound 3, concentration for total growth inhibition: 6600 nM
The estimate for compound 3 lay 6.8-fold (0.83 log units) above the measured number; the whole stated range lies above it.
By their numbers in this assay, from the lowest: compound 3; then compounds 2 and 1 (each within the scatter of the next).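

In this assay, replacing the amino group on the aromatic carbon between two ring nitrogen atoms with hydrogen gives a 6.0-fold lower number from compound 1 to compound 3 (0.78 log units; beyond the scatter). This shows that the position matters for growth inhibition and that, in this pair, hydrogen there gives the stronger inhibitor. Nothing available explains why the number falls. Going by these compounds, it remains open how a methyl or a methoxy group on that carbon would compare, and whether the same change would have a similar effect on other compounds.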